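Amine tail change on a second benzimidazole core

A few compounds are considered here, and "the series" means these few. Any claim that something is new, unique, unknown or untested is made for them only; others in the source may bear on it.

Measured so far in a functional assay on HL60/MX2 cells (Homo sapiens) for antiproliferative activity, read by MTT assay, with a stated time of 48 h; a higher number here means a weaker inhibitor, a lower number a stronger inhibitor:
compound 1 `CCN(CC)CCCn1c(N)c(-c2nc3ccccc3n2C)c2nc(C#N)c(C#N)nc21` gives 4470 nM
compound 2 `CN(C)CCCCn1c(N)c(-c2nc3ccccc3n2C)c2nc(C#N)c(C#N)nc21` gives 2580 nM
compound 3 `CCN(CC)CCCn1c(N)c(-c2nc3cc(Cl)ccc3[nH]2)c2nc(C#N)c(C#N)nc21` gives 2460 nM

Compound 4 `CN(C)CCCCn1c(N)c(-c2nc3cc(Cl)ccc3[nH]2)c2nc(C#N)c(C#N)nc21` is not yet measured. It stands to compound 3 as compound 2 stands to compound 1: the change is (dimethylamino)methyl in place of diethylamino on a saturated chain carbon, three bonds along the chain from an aromatic nitrogen, the same kind of change as (dimethylamino)methyl in place of diethylamino on a saturated chain carbon, three bonds along the chain from an aromatic nitrogen, and the two place descriptions read alike word for word. On the core of compound 1 that change gave a 1.7-fold lower number from compound 1 to compound 2 (0.24 log units; within the scatter). The cores of compound 3 and compound 1 differ by 5-chloro-1H-benzimidazol-2-yl in place of 1-methyl-1H-benzimidazol-2-yl on an aromatic carbon, a change that gave a 1.8-fold lower number from compound 1 to compound 3 (0.26 log units; within the scatter).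

Compound 4 is therefore expected to move from compound 3 by about a 1.5-fold lower number from compound 3 to compound 4 (0.19 log units; within the scatter), resting on the step of a 1.7-fold lower number from compound 1 to compound 2 (0.24 log units; within the scatter) seen on the other core. The estimate for compound 4 in this assay is 1600 nM, expected to fall between 700 nM and 3600 nM.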

Compound 4, half-maximal inhibitory concentration: 580 nM
For compound 4 the middle estimate is 2.8-fold (0.44 log units) above the measured one; the measured number lies below the stated range.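

In this assay, 4-(dimethylamino)butyl in place of 3-(diethylamino)propyl gives a 4.2-fold lower number from compound 3 to compound 4 (0.63 log units; beyond the scatter), beyond the scatter on this core, yet the step does not differ measurably from the one on the core of compound 1: the same change on two cores in this assay, a 1.7-fold lower number (0.24 log units; within the scatter) from compound 1 to compound 2 and a 4.2-fold lower number (0.63 log units; beyond the scatter) from compound 3 to compound 4, 2.4-fold (0.39 log units) apart, within the scatter of two such steps. The benzimidazole change on the 4-(dimethylamino)butyl tail, which gives a 4.4-fold lower number from compound 2 to compound 4 (0.65 log units; beyond the scatter), reads the same way: the same change on two cores in this assay, a 1.8-fold lower number (0.26 log units; within the scatter) from compound 1 to compound 3 and a 4.4-fold lower number (0.65 log units; beyond the scatter) from compound 2 to compound 4, 2.4-fold (0.39 log units) apart, within the scatter of two such steps. Both changes are therefore consistent with carrying across in this small set, but with one pair per core this neither proves additivity nor shows a real interaction between tail and core.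

The tail change alters chain length and amine substituents together, so 4-(diethylamino)butyl and 3-(dimethylamino)propyl tails would be needed to separate them. From the compounds shown here alone, whether the step holds for a cyclic amine such as morpholine also remains open.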